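A few compounds are considered here, and "the series" means these few. Any claim that something is new, unique, unknown or untested is made for them only; others in the source may bear on it.

Of the compounds shown here, three built on one shared core have been tested in an ADME assay on MT2 cells (Homo sapiens) for cytotoxicity, read by XTT assay, with a stated time of 4 days; on this read-out higher numbers stand for lower toxicity in this test and lower numbers for higher toxicity in this test. Compound 1 `Cc1cc(/C=C2\SC(=S)N(c3cccc(O)c3)C2=O)c(C)n1-c1cccc(-c2nnn[nH]2)c1` gives 35600 nM. Compound 2 `COc1ccc(N2C(=O)/C(=C/c3cc(C)n(-c4cccc(-c5nnn[nH]5)c4)c3C)SC2=S)cc1` gives 87000 nM in this assay. Compound 3 `Cc1cc(/C=C2\SC(=S)N(c3ccc(C(F)(F)F)cc3)C2=O)c(C)n1-c1cccc(-c2nnn[nH]2)c1` gives 27100 nM in this assay. Compound 3 thus carries the lowest of the three numbers, which on this read-out points to the higher toxicity, although its gap to compound 1 is within the scatter, since a 1.3-fold lower number from compound 1 to compound 3 (0.12 log units; within the scatter). Its gap to compound 2 is wider: a 3.2-fold lower number from compound 2 to compound 3 (0.51 log units; beyond the scatter).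

Compound 4 `Cc1cc(/C=C2\SC(=S)N(c3ccc(O)cc3)C2=O)c(C)n1-c1cccc(-c2nnn[nH]2)c1` has not yet been measured. It differs from compound 3 in one place: hydroxy in place of trifluoromethyl on an aromatic carbon. Among the measured compounds shown here, two measured steps bear on this change. One swapped a hydroxyphenyl for the trifluoromethylphenyl of compound 3 and left the number within the scatter, as shown by the step from compound 1 quoted above. The other exchanged methoxy for trifluoromethyl on the same aromatic carbon and lowered the number, as the step from compound 2 shows. Going back from trifluoromethyl to a hydroxy, a group that compound 1 also carries on its phenyl, suggests at most a small rise. The expected step is a 1.5-fold higher number from compound 3 to compound 4 (0.17 log units; within the scatter). Compound 4 is therefore estimated at 40000 nM in this assay, with a range from 20000 nM to 80000 nM.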

Compound 4, half-maximal cytotoxic concentration: 45600 nM
Compound 4: middle estimate off by 1.1-fold (0.06 log units), on the low side; the range from low to high includes it.
By their numbers in this assay, from the lowest: compounds 3, 1, 4 and 2 (each within the scatter of the next, the first and the last beyond it).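

In this assay, trading the trifluoromethyl of compound 3 for hydroxy on this aromatic carbon brings in a hydrogen-bond donor and a hydrogen-bond acceptor, yet the number stays within the scatter (a 1.7-fold higher number from compound 3 to compound 4 (0.23 log units; within the scatter)). Compound 4 also stays within the scatter of its two other neighbours, both when the methyl on the oxygen is replaced by hydrogen (a 1.9-fold lower number from compound 2 to compound 4 (0.28 log units; within the scatter)) and when 4-hydroxyphenyl stands in place of 3-hydroxyphenyl (a 1.3-fold higher number from compound 1 to compound 4 (0.11 log units; within the scatter)). So although compound 2 and compound 3 lie beyond the scatter of each other, compound 4 lies within the scatter of both, which sets the hydroxy apart from none of the groups it was compared with here, and nothing available explains why these numbers lie so close.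

The compounds shown leave open whether an amine or a carboxylic acid on the same aromatic carbon would also stay within the scatter of these compounds or would move the number beyond it. They also leave open what a longer chain on the oxygen, such as ethoxy, would do, as methoxy and hydroxy are the only oxygen-linked groups shown at this place.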